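Trifluoromethyl for Ethyl on the Pendant Phenyl Ring

The compounds below may be only part of what the source reports. "The series", "measured", "known", "first", "only" and "open" are said of these compounds alone.

Compound 1 `O=C(Nc1cc2cc[nH]c(=O)c2cc1Cl)C1CNCC1c1ccccn1`: 14 nM
Compound 2 `CCc1cccc(C2CNCC2C(=O)Nc2cc3cc[nH]c(=O)c3cc2Cl)c1`: 4 nM
Compound 3 `O=C(Nc1cc2cc[nH]c(=O)c2cc1Cl)C1CNCC1c1cccc(C(F)(F)F)c1`: not yet measured

In an assay on isolated protein for inhibition of Rho-associated protein kinase 2 (Homo sapiens), read by a luciferase reporter (on this read-out higher numbers stand for weaker inhibition and lower numbers for stronger inhibition), compound 1 gives 14 nM and compound 2 gives 4 nM. Compound 2 stands at the lowest of the two numbers, the stronger inhibitor, separated from compound 1 by a 3.5-fold lower number from compound 1 to compound 2 (0.54 log units; beyond the scatter). Compound 3 carries trifluoromethyl in place of ethyl on an aromatic carbon. Among the compounds with values here, the only measured step swaps a whole ring, so it does not bear on this substituent change; the expectation for compound 3 is therefore no step beyond the scatter, a 1.3-fold higher number from compound 2 to compound 3 (0.10 log units; within the scatter). Compound 3 is estimated at 5 nM, within 2 nM to 15 nM.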

Compound 3, half-maximal inhibitory concentration: 4 nM
Compound 3: middle estimate off by 1.3-fold (0.10 log units), on the high side, and the stated range covers the measured number.
By their numbers in this assay, from the lowest: compounds 2 and 3 (each within the scatter of the next); then compound 1.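

In this assay, trifluoromethyl in place of ethyl on this aromatic carbon gives no change at the digits printed from compound 2 to compound 3 (within the scatter), so the position tolerates both groups, even though the entering group has more heavy atoms and brings fluorine. Going from pyridin-2-yl to 3-(trifluoromethyl)phenyl gives a 3.5-fold lower number from compound 1 to compound 3 (0.54 log units; beyond the scatter), a step the same size as the one to 3-ethylphenyl. Nothing available explains why the two groups read alike. As far as these compounds go, whether an amine, a carboxylic acid or a longer chain such as butyl would also be tolerated here remains open.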